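Moving the Fluorine on a Weak Binder Series

The source may hold more compounds than are shown below. What is called first, only, known or untested is meant among the compounds shown, and "the series" means these compounds.

compound 1 `COc1ccccc1NC(=O)N[C@@H]1C2CCN(CC2)[C@@H]1Cc1cccnc1` — > 10000 nM
compound 2 `CSc1ccc(NC(=O)N[C@@H]2C3CCN(CC3)[C@@H]2Cc2cccnc2)cc1` — > 10000 nM
compound 3 `O=C(Nc1ccc(F)cc1)N[C@@H]1C2CCN(CC2)[C@@H]1Cc1cccnc1` — > 10000 nM

Three compounds share the core of compound 1 and differ only in the aryl group on the amide-type nitrogen. In an assay on a protein complex for binding affinity to Neuronal acetylcholine receptor; alpha4/beta2 (Homo sapiens) (on this read-out higher numbers stand for weaker inhibition and lower numbers for stronger inhibition), compound 1 is reported only as a limit, > 10000 nM. Compound 2 is likewise reported as a limit in this assay, > 10000 nM. Compound 3 too stands at a limit in this assay, > 10000 nM, so its true position is not a number but a boundary. The measured steps are accordingly uninformative: one reads a step that the two limits leave unreadable from compound 1 to compound 2, another a step that the two limits leave unreadable from compound 1 to compound 3, a third step that the two limits leave unreadable from compound 2 to compound 3. What the three have in common is the limit of > 10000 nM in this assay, at which 3 of the 3 values shown sit.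

Compound 4 `O=C(Nc1cccc(F)c1)N[C@@H]1C2CCN(CC2)[C@@H]1Cc1cccnc1` differs from compound 3 in one place: 3-fluorophenyl in place of 4-fluorophenyl on an amide-type nitrogen. For the measured compounds named here, no measured step bears on this change in a readable way, and every measured neighbour sits at the limit, so the expected step in this assay, a step that the limit leaves unreadable from compound 3 to compound 4, is none that the numbers could resolve. Compound 4 is therefore expected to give about 15000 nM in this assay, within 5000 nM to 60000 nM, and most probably to be reported once more only as a limit.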

Compound 4, inhibition constant: > 10000 nM
Compound 4: a limit, no number; the forecaster's own chance of this, stated with the estimate: 85%; the middle value is on the limit's open side.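

Compound 4 is also reported only as a limit, so no step can be read between it and compound 1, compound 2 or compound 3 in this assay: the limit of > 10000 nM in this assay, at which 4 of the 4 values shown sit. The compounds shown leave open how far each lies beyond that limit, and whether any aryl group on the amide-type nitrogen of the shared core would give a measurable number.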